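A Second Chloro on the Core of Compound 2

The source may report more compounds than this note shows. Statements on the series, on what has been measured and on what is new or still open speak of the compounds shown alone.

Compound 1 `ClCc1ccc(Cn2cnc3c(Cl)ncnc32)cc1` and compound 2 `ClCc1ccccc1Cn1cnc2ncnc(Cl)c21` are built from the same atoms joined differently; the difference between the two cores is not broken down here. In a functional assay on A498 cells (Homo sapiens) for cytotoxicity, read by sulforhodamine B assay, with a stated time of 48 h (on this read-out higher numbers stand for weaker inhibition of growth and lower numbers for stronger inhibition of growth), compound 1 gives 26900 nM, and compound 2 gives 33100 nM, two numbers that lie within the scatter of each other. Compound 3 `ClCc1ccc(Cn2cnc3c(Cl)nc(Cl)nc32)cc1` carries chloro in place of hydrogen on an aromatic carbon, and this change gave a 1.1-fold lower number from compound 1 to compound 3 (0.03 log units; within the scatter), so that compound 3 gives 25100 nM. Compound 4 `ClCc1ccccc1Cn1cnc2nc(Cl)nc(Cl)c21` has not yet been measured; it carries chloro in place of hydrogen on an aromatic carbon, the same change applied to the core of compound 2. Because the step of a 1.1-fold lower number from compound 1 to compound 3 (0.03 log units; within the scatter) stayed within the scatter, the step in this assay is expected to be small as well, about a 1.1-fold lower number from compound 2 to compound 4 (0.04 log units; within the scatter). Compound 4 is therefore estimated at 30000 nM, with a likely range from 15000 nM to 60000 nM.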

Compound 4, concentration for total growth inhibition: 5880 nM
Compound 4: the middle estimate sits 5.1-fold (0.71 log units) above what was measured; the whole stated range lies above it.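

In this assay, chloro in place of hydrogen on an aromatic carbon gave a 5.6-fold lower number from compound 2 to compound 4 (0.75 log units; beyond the scatter), and the size of the step did not carry over from one core to the other: the same change on two cores in this assay, a 1.1-fold lower number (0.03 log units; within the scatter) from compound 1 to compound 3 and a 5.6-fold lower number (0.75 log units; beyond the scatter) from compound 2 to compound 4, 5.3-fold (0.72 log units) apart, beyond the scatter of two such steps. In this series, then, the step measured on the core of compound 1 was a poor guide to the same change on the core of compound 2. This pair does not show why the two cores differ, and two cores give no rule for any other.

The compounds shown leave open whether an amine or a methoxy group in the same place would also give different steps on the two cores. They also leave open how the chloro change would behave on a third core.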